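Notes on the fluoro step from compound 3

A few compounds are considered here, and "the series" means these few. Any claim that something is new, unique, unknown or untested is made for them only; others in the source may bear on it.

Measured in a functional assay on A-375 cells (Homo sapiens) for cytotoxicity, read by CCK-8 assay, with a stated time of 24 h; on this read-out lower numbers stand for stronger inhibition and higher numbers for weaker inhibition
- compound 1 `COc1ccccc1Oc1c(N)nc(-c2ccccc2)nc1Cl` gives 7220 nM
- compound 2 `COc1ccccc1Oc1c(N)nc(-c2cccc(Cl)c2)nc1Cl` gives 38300 nM
- compound 3 `COc1ccccc1Oc1c(N)nc(-c2ccccc2)nc1OCCO` gives > 80000 nM as a limit, not a number

Compound 3 stands at the limit of > 80000 nM in this assay, at which 1 of the 3 values shown sits, and so has no number of its own. Compound 4 `COc1ccccc1Oc1c(N)nc(-c2cccc(F)c2)nc1OCCO` differs from it by fluoro in place of hydrogen on an aromatic carbon. Within the data shown here, no fluoro step has been measured. The closest one is the chloro exchange, a 5.3-fold higher number from compound 1 to compound 2 (0.72 log units; beyond the scatter), and the other measured step, an at least 11-fold higher number from compound 1 to compound 3 (1.04 log units; beyond the scatter), is already carried by compound 4. A modest step towards higher numbers in this assay is therefore expected, and another limit is likely. The expected step is a step that the limit leaves unreadable from compound 3 to compound 4 in this estimate. For compound 4 the estimated value is 90000 nM, with an expected range from 30000 nM to 200000 nM.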

Compound 4, half-maximal inhibitory concentration: 8530 nM
Beside the measured number, compound 4's estimate is 11-fold (1.02 log units) above it, and the stated range ends above it.
By their numbers in this assay, from the lowest: compounds 1 and 4 (each within the scatter of the next); then compound 2. At a limit, above all of these: compound 3.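

In this assay, a substituent on the phenyl ring can move the number down as well as up: the fluoro exchange gives an at least 9.3-fold lower number from compound 3 to compound 4 (0.97 log units; beyond the scatter), whereas the chloro exchange gave a 5.3-fold higher number from compound 1 to compound 2 (0.72 log units; beyond the scatter). These two steps differ both in the halogen and in the group held constant elsewhere, 2-hydroxyethoxy or chloro. Compound 3 is a limit, not a number, so the fluoro step has only a lower bound: the limit of > 80000 nM in this assay, at which 1 of the 4 values shown sits.

The compounds shown leave open whether the direction follows the halogen or the 2-hydroxyethoxy group. Also open, going by these compounds, is how an amine or a longer chain in place of 2-hydroxyethoxy would read.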